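The source may hold more compounds than are shown below. What is called first, only, known or untested is meant among the compounds shown, and "the series" means these compounds.

Working notes on the series. The shared read-out is an assay on isolated protein (strain Sprague-Dawley) for inhibition of Amine oxidase [flavin-containing] A (Rattus norvegicus), read by spectrophotometry, with a stated time of 5 min, tested at 10 uM; on this read-out lower numbers stand for less inhibition and higher numbers for more inhibition at the one concentration tested (going by the name of the read-out). Compound 1, `O=c1cc(O)c2ccc(OCc3cccc(Br)c3)cc2o1`, gives 0% in this assay. Compound 2, `CC(C)Oc1cc(=O)oc2cc(OCc3cccc(Cl)c3)ccc12`, gives 3%. Compound 3, `COCOc1cc(=O)oc2cc(OCc3cccc(Cl)c3)ccc12`, gives 23%. Within the data shown here, the one single-point step among the measured compounds is a number 20 percentage points higher from compound 2 to compound 3 (beyond the scatter). On the numbers shown, compound 3 stands highest of the three: its nearest neighbour is compound 2, lower by a step beyond the scatter, and the furthest is compound 1, lower by a gap that also lies beyond the scatter.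

The next compound is compound 4, `CCOC(=O)COc1cc(=O)oc2cc(OCc3cccc(Cl)c3)ccc12`. Its difference from compound 3 is ethoxycarbonyl in place of methoxy on a saturated chain carbon bound to an oxygen on an aromatic ring. Among the measured compounds shown here, only one measured step bears on this change, the exchange at the oxygen on the aromatic ring between compound 2 and compound 3, which moved the read-out by a modest amount beyond the scatter; no measured pair exchanges a methoxy for an ethoxycarbonyl on a saturated chain carbon, so the direction of the new step is not fixed by the data. The expectation is therefore a step of a number 8 percentage points lower from compound 3 to compound 4 (within the scatter) in this assay, which may fall within the scatter. Compound 4 is estimated at 15%, with a range from 0% to 38%.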

Compound 4, a percentage reported as inhibition, at one concentration (the size of the read-out at that concentration, not a potency): 0%
Compound 4: middle estimate off by 15 percentage points, on the high side; measured number inside the range.
By their numbers in this assay, from the lowest: compounds 1, 4 and 2 (each within the scatter of the next); then compound 3.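

At the saturated chain carbon bound to an oxygen on an aromatic ring, ethoxycarbonyl in place of methoxy in this assay gives a number 23 percentage points lower from compound 3 to compound 4 (beyond the scatter) and so does not keep the level reached with methoxymethyl on this oxygen. Against isopropyl, the same side chain gives a number 3 percentage points lower from compound 2 to compound 4 (within the scatter) and cannot be told apart from it, which leaves methoxymethyl as the only one of these three groups on this oxygen that stands clear of the other two. Nothing measured here bears on the reason for the difference between the methoxy and ethoxycarbonyl ends of the chain.

The compounds shown leave open whether the higher number for compound 3 depends on the ether oxygen in its chain, a question that a plain ethyl or propyl group or a longer methoxyethyl chain on the same oxygen would address. They also leave open whether a carboxylic acid, an amide or an amine at the end of the chain would behave like ethoxycarbonyl or like methoxy in this assay on this shared core.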